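A 2-carboxyethyl group replaces isopropyl in compound 2

The source may hold more compounds than are shown below. What is called first, only, known or untested is meant among the compounds shown, and "the series" means these compounds.

Among the compounds with values here, in a functional assay on MCF7 cells (Homo sapiens) for antiproliferative activity, read by MTT assay, with a stated time of 24 h (on this read-out lower numbers stand for stronger inhibition and higher numbers for weaker inhibition), compound 1 `CCn1c(C(=O)NC2(CO)CC2)ccc1C(CC)(CC)c1ccc(OCS(=O)(=O)c2ccccc2)c(C)c1` gives 28800 nM and compound 2 `CCn1c(C(=O)N[C@@H](C(=O)O)C(C)C)ccc1C(CC)(CC)c1ccc(OCS(=O)(=O)c2ccccc2)c(C)c1` gives 44700 nM so compound 2 lies within the scatter of the only other measured number. Compound 3 `CCn1c(C(=O)N[C@H](CCC(=O)O)C(=O)O)ccc1C(CC)(CC)c1ccc(OCS(=O)(=O)c2ccccc2)c(C)c1` differs from compound 2 by one change 2-carboxyethyl in place of isopropyl on a saturated chain carbon bound to an amide-type nitrogen and a carbonyl carbon in which 2-carboxyethyl stands in place of isopropyl on a saturated chain carbon bound to an amide-type nitrogen and a carbonyl carbon. Within the data shown here, only one measured step bears on this: a 1.6-fold higher number from compound 1 to compound 2 (0.19 log units; within the scatter) is a different change on the same amide-type nitrogen, and it stays within the scatter. That single small step is thin evidence, but it gives no reason to expect a shift beyond the scatter in this assay in either direction. The expected step of a 1.0-fold higher number from compound 2 to compound 3 (0.00 log units; within the scatter) is therefore small. Compound 3 is estimated at 45000 nM with an expected range from 22000 nM to 95000 nM for its measurement.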

Compound 3, half-maximal inhibitory concentration: > 50000 nM
Compound 3: only a limit was reported (the forecaster's own chance of this, stated with the estimate: 25%); middle value at least 1.1-fold (0.04 log units) from the limit.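

In this assay compound 3 gives > 50000 nM, which is a limit and not a number. Within the data shown here, putting 2-carboxyethyl in place of isopropyl on this saturated chain carbon gives an at least 1.1-fold higher number from compound 2 to compound 3 (0.04 log units; that floor lies within the scatter), and putting 1,3-dicarboxypropyl in place of 1-(hydroxymethyl)cyclopropyl on the amide-type nitrogen gives an at least 1.7-fold higher number from compound 1 to compound 3 (0.23 log units; that floor lies within the scatter), so neither change brings the number down, which the earlier compounds could not show for this group. Whether either step truly goes beyond the scatter cannot be read, and the size of any rise stays unknown: the limit of > 50000 nM in this assay, at which 1 of the 3 values shown sits.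

Still open, as far as these compounds go, is how a 2-aminoethyl group or a carboxymethyl group on the same carbon would read. From the compounds shown here alone, a longer chain ending in a primary amide instead of a carboxylic acid is equally open.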